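The compounds below may be only part of what the source reports. "The series", "measured", "known", "first", "only" and "open" are said of these compounds alone.

Measured compounds, growth inhibition of the breast epithelial line:

compound 1 `CS/C(=N\C(=O)c1cc2ccccc2s1)NC(=O)c1cc2ccccc2s1`: 20 nM
compound 2 `O=C(/N=C(/NC(=O)c1cc2ccccc2s1)[Se]Cc1ccccc1)c1cc2ccccc2s1`: 37900 nM
compound 3 `CS/C(=N\C(=O)c1cnc2ccccc2c1)NC(=O)c1cnc2ccccc2c1`: 500 nM

The series is measured in an ADME assay on MCF-10A cells (Homo sapiens) for cytotoxicity, read by MTT assay, with a stated time of 72 h; a lower number here means a stronger inhibitor of growth, a higher number a weaker inhibitor of growth. Compound 1 gives the lowest number of the three. One structural change is made within the first pair: a group of 8 heavy atoms (7 carbon, 1 selenium; one six-membered aromatic ring of carbon only) in place of a group of 2 heavy atoms (1 carbon, 1 sulfur; no ring), on a carbon with a double bond to nitrogen. Its effect is a 1900-fold higher number from compound 1 to compound 2 (3.28 log units; beyond the scatter), by far the largest movement in the set. Compound 3 carries a different core from compound 1; the difference between the two cores is not broken down here. What the two values show is that compound 3 sits higher than compound 1, and lower than compound 2.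

Compound 4 `O=C(/N=C(/NC(=O)c1cnc2ccccc2c1)[Se]Cc1ccccc1)c1cnc2ccccc2c1` has not yet been measured in this assay. It stands to compound 3 as compound 2 stands to compound 1, the same change on the same kind of place: a group of 8 heavy atoms (7 carbon, 1 selenium; one six-membered aromatic ring of carbon only) in place of a group of 2 heavy atoms (1 carbon, 1 sulfur; no ring), on a carbon with a double bond to nitrogen. Within the data shown here, the only precedent for this change is the single step seen between compound 1 and compound 2, so the expectation rests on that one observation and on the starting point of compound 3, which already reads higher than compound 1 in this assay. Among the measured compounds shown here, the step expected from compound 3 to compound 4 is estimated as a 400-fold higher number from compound 3 to compound 4 (2.60 log units; beyond the scatter), placed beside the measured one because a 1900-fold higher number from compound 1 to compound 2 (3.28 log units; beyond the scatter) is the only guide available, and allowing that the second core may not carry the change to the same extent. On that basis compound 4 is expected to give about 200000 nM in this assay, with a plausible range from 30000 nM to 1000000 nM; a value this high may well come back only as a limit of the assay.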

Compound 4, concentration for 50% growth inhibition: 23600 nM
For compound 4 the middle estimate is 8.5-fold (0.93 log units) above the measured one; the measured number lies below the stated range.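

On the second core, the exchange of methylsulfanyl for the entering group with selenium and an aromatic ring again moves the read-out in the same direction in this assay, giving a 47-fold higher number from compound 3 to compound 4 (1.67 log units; beyond the scatter), so the direction of the change holds on both cores shown. Among these compounds, the size of the change does not carry over unchanged from one core to the other, and the two steps differ by more than the scatter of such steps: the same change on two cores in this assay, a 1900-fold higher number (3.28 log units; beyond the scatter) from compound 1 to compound 2 and a 47-fold higher number (1.67 log units; beyond the scatter) from compound 3 to compound 4, 40-fold (1.60 log units) apart, beyond the scatter of two such steps With only two matched pairs, this shows that the core can alter how much the change matters, but it gives neither a general rule for other cores nor a reason for the gap.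

It remains open which part of the entering group accounts for the step, the selenium or the aromatic ring, which could be separated by pairing a sulfur atom with the same ring, or selenium with a simple methyl group. Also open, going by these compounds, is how an amine or a longer alkyl chain would behave on the carbon with a double bond to nitrogen, and how large the step would be on a third core.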